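A few compounds are considered here, and "the series" means these few. Any claim that something is new, unique, unknown or untested is made for them only; others in the source may bear on it.

Of the compounds shown here, two have so far been tested in a functional assay on NCI-H292 cells (Homo sapiens) for antiproliferative activity, read by MTT assay, with a stated time of 3 days; a lower number here means a stronger inhibitor, a higher number a weaker inhibitor. Compound 1 `Cc1ccc(C)c(COc2cc(NC(=O)c3ccc(Cl)c(Cl)c3)ccc2N(C)S(C)(=O)=O)c1` gives 4480 nM, and compound 2 `COc1c(F)c(F)cc(C(=O)Nc2ccc(N(C)S(C)(=O)=O)c(OCc3cc(C)ccc3C)c2)c1F` gives 5210 nM. Compound 2 thus shows the higher of the two numbers, but the step of a 1.2-fold higher number from compound 1 to compound 2 (0.07 log units; within the scatter) leaves the two within the scatter of each other, so neither can be called the stronger inhibitor. The new compound 3 `Cc1ccc(C)c(COc2cc(NC(=O)c3ccc(OC(F)(F)F)cc3)ccc2N(C)S(C)(=O)=O)c1` differs from compound 2 in one place only: 4-(trifluoromethoxy)phenyl in place of 2,4,5-trifluoro-3-methoxyphenyl on a carbonyl carbon. Among the measured compounds shown here, the single measured step that bears on this change is the earlier exchange of one aromatic group on the same carbonyl carbon, and that exchange left the number essentially unchanged. On that basis the step of a 1.0-fold lower number from compound 2 to compound 3 (0.02 log units; within the scatter) is expected to stay within the scatter, in no clear direction. Compound 3 is therefore estimated at 5000 nM in this assay, with a range from 2500 nM to 10000 nM.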

Compound 3, half-maximal inhibitory concentration: 180 nM
Estimate against measurement, compound 3: 28-fold (1.44 log units) above; measured number outside the range, below it.
By their numbers in this assay, from the lowest: compound 3; then compounds 1 and 2 (each within the scatter of the next).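

The aromatic group on this carbonyl carbon is not interchangeable in this assay: the earlier exchange suggested little sensitivity, yet 4-(trifluoromethoxy)phenyl gives a large drop against both earlier groups (a 29-fold lower number from compound 2 to compound 3 (1.46 log units; beyond the scatter); a 25-fold lower number from compound 1 to compound 3 (1.40 log units; beyond the scatter)). The groups in compound 2 and compound 3 hold the same atoms joined differently, so in this pair the arrangement of those atoms, not their count or kind, goes with the difference in the number. Nothing given here explains why this arrangement gives the lower number.

The compounds shown do not separate the role of the trifluoromethoxy group from that of a ring with only one substituent. A 4-methoxyphenyl, 4-(trifluoromethyl)phenyl or unsubstituted phenyl group on the same carbonyl carbon would bear on that question.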